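Phenyl for Methyl at the Carbonyl of Compound 3

A few compounds are considered here, and "the series" means these few. Any claim that something is new, unique, unknown or untested is made for them only; others in the source may bear on it.

Of the compounds shown here, three have been tested in a functional assay on CAKI-1 cells (Homo sapiens) for inhibition, read by sulforhodamine B assay, with a stated time of 48 h; on this read-out higher numbers stand for weaker inhibition of growth and lower numbers for stronger inhibition of growth. Compound 1 `COc1ccc2[nH]c(-c3ccccc3)c(C=C(C#N)C#N)c2c1` gives 4100 nM, compound 2 `COc1ccc(-c2[nH]c3ccc(OC)cc3c2/C=C(\C#N)S(=O)(=O)c2ccccc2)cc1` gives 4200 nM, and compound 3 `CC(=O)/C(=C\c1c(-c2ccccc2)[nH]c2ccccc12)S(=O)(=O)c1ccccc1` gives 2400 nM. Compound 3 has the lowest of these three numbers, but its gaps to compound 1 and to compound 2 both lie within the usual scatter, so the three cannot be told apart. Compound 4 `O=C(/C(=C\c1c(-c2ccccc2)[nH]c2ccccc12)S(=O)(=O)c1ccccc1)c1ccccc1` differs from compound 3 in one place: phenyl in place of methyl on a carbonyl carbon, which cut one bond further out reads acetyl to benzoyl. Within the data shown here, no measured pair shows this change, so there is nothing to scale it by. The expected step is small, within the scatter, in either direction: a 1.1-fold lower number from compound 3 to compound 4 (0.04 log units; within the scatter). Compound 4 is therefore estimated to give 2200 nM, within 700 nM to 7000 nM.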

Compound 4, concentration for 50% growth inhibition: 3100 nM
Estimate against measurement, compound 4: 1.4-fold (0.15 log units) below, within the range that was stated.
By their numbers in this assay, from the lowest: compounds 3, 4, 1 and 2 (each within the scatter of the next).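

In this assay, phenyl in place of methyl on a carbonyl carbon gives a 1.3-fold higher number from compound 3 to compound 4 (0.11 log units; within the scatter) and so leaves the number within the scatter, even though the six-membered aromatic ring brings six heavy atoms where methyl has one. At this position, acetyl and benzoyl cannot be told apart on this read-out. Nothing measured here explains this result. The compounds shown leave open whether an amine, a carboxylic acid or a longer chain such as butyl on this carbonyl carbon would give a number beyond the scatter from compound 3.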